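The source may hold more compounds than are shown below. What is called first, only, known or untested is meant among the compounds shown, and "the series" means these compounds.

Four compounds share one core, and three of them have been tested in a functional assay on PC-3 cells (Homo sapiens) for antiproliferative activity, read by MTT assay, with a stated time of 48 h; on this read-out higher numbers stand for weaker inhibition and lower numbers for stronger inhibition. Compound 1 `CS(=O)(=O)c1ccc(Nc2ncc(F)c(Nc3nc4ccccc4s3)n2)cc1` gives 2830 nM in this assay. Within the data shown here, compound 2 `NS(=O)(=O)c1ccc(Nc2nccc(Nc3nc4ccccc4s3)n2)cc1` gives 3100 nM in this assay, a value that lies within the usual scatter of the one for compound 1. Compound 3 `CS(=O)(=O)c1ccc(Nc2nccc(Nc3nc4ccc(Cl)cc4s3)n2)cc1` stands apart: in this assay compound 3 returns only > 50000 nM, which is a limit of the assay and not a measured number. Among the measured compounds shown here, compound 3 is the one value sitting at the limit of > 50000 nM in this assay, at which 1 of the 3 values shown sits.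

Compound 4 `CS(=O)(=O)c1ccc(Nc2nccc(Nc3nc4ccccc4s3)n2)cc1` has not been measured. It differs from compound 3 by hydrogen in place of chloro on an aromatic carbon. For the measured compounds named here, no measured step connects compound 3 to any neighbour, so the size of this step is an expectation only. The step from compound 3 to compound 4 is expected to be an at least 16-fold lower number from compound 3 to compound 4 (1.22 log units; beyond the scatter), toward stronger inhibition, well beyond the scatter. This rests on compound 1 with 2830 nM and compound 2 with 3100 nM, both of which lack the chloro. Compound 4 is therefore expected to give about 3000 nM in this assay, with a likely range from 1000 nM to 12000 nM.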

Compound 4, half-maximal inhibitory concentration: 1710 nM
Estimate against measurement, compound 4: 1.8-fold (0.24 log units) above, and the stated range covers the measured number.
By their numbers in this assay, from the lowest: compounds 4, 1 and 2 (each within the scatter of the next). At a limit, above all of these: compound 3.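

Among these compounds, removing the chloro gives, in this assay, an at least 29-fold lower number from compound 3 to compound 4 (1.46 log units; beyond the scatter), so this one position carries a far larger change than anything the earlier compounds could show. The figure for compound 3 is a limit and not a number, so the true size of this step stays unknown: the limit of > 50000 nM in this assay, at which 1 of the 4 values shown sits.

By contrast, two other single changes stay within the scatter: a 1.8-fold lower number from compound 2 to compound 4 (0.26 log units; within the scatter) with methyl in place of amino on the sulfonyl sulfur, and a 1.7-fold lower number from compound 1 to compound 4 (0.22 log units; within the scatter) with the fluoro removed.

Going by these compounds, whether bromo, methoxy or nitrile at the chloro position would read like chloro or like hydrogen remains open. On these data alone, how an ethyl group on the sulfonyl sulfur would read also remains open.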